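Bromo for Hydroxy on a Shared Hydrazide Scaffold

This account rests on a few compounds, and the source may have more. Where it says the series, first, only, none or still open, it means among the compounds named here.

The three measured compounds share a core and differ only in the aryl group bearing the imine. Compound 1 `O=C(COc1cccc2ccccc12)N/N=C/c1c(O)ccc2ccccc12` gives 4.74 in a physicochemical assay for lipophilicity, measured as octanol-water partition; on this read-out lower numbers stand for lower lipophilicity and higher numbers for higher lipophilicity. Compound 2 `O=C(COc1cccc2ccccc12)N/N=C/c1ccc(O)cc1` gives 3.73 in this assay, and compound 3 `O=C(COc1cccc2ccccc12)N/N=C/c1cccc([N+](=O)[O-])c1` gives 3.97. On these numbers compound 2 and compound 3 sit within the scatter of each other, while compound 1 stands higher than compound 2 by a gap that lies beyond the scatter.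

Compound 4 `O=C(COc1cccc2ccccc12)N/N=C/c1ccc(Br)cc1` is not yet measured. It is reached from compound 2 by one change: bromo in place of hydroxy on an aromatic carbon. Within the data shown here, no measured pair shows this exact change, so no step can be read directly from the data. The step from compound 2 to compound 4 is expected to be upward in this assay and to lie beyond the scatter, at about a number 1.47 log units higher from compound 2 to compound 4 (beyond the scatter). Compound 4 is therefore estimated at 5.2, with a range from 4.8 to 5.6.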

Compound 4, partition coefficient: 4.81
Estimate against measurement, compound 4: 0.39 log units above, and the stated range covers the measured number.
By their numbers in this assay, from the lowest: compounds 2 and 3 (each within the scatter of the next); then compounds 1 and 4 (each within the scatter of the next).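

In this assay, among these compounds, putting bromo in place of hydroxy on an aromatic carbon, para to a large group, comes out as a number 1.08 log units higher from compound 2 to compound 4 (beyond the scatter) and is the only single change in this set with a step that can be read directly. The earlier compounds shown here gave separate values for different aryl groups with no step between them, whereas this pair shows that the read-out responds strongly to the group at this position. No measurement in hand bears on what lies behind this step.

With only one step available, the compounds shown leave open whether the same change would give a similar step on the other aryl groups in the set. They also leave open how an amine, a carboxylic acid, a methoxy group or chloro would read at this position.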